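This account rests on a few compounds, and the source may have more. Where it says the series, first, only, none or still open, it means among the compounds named here.

Working notes on the series. Compound 1 `COc1ccc(-c2c(C)sc3c(N4CC[C@@H](NC(C)=O)C4)nc(C)nc23)cc1OC` in an ADME assay on microsomes from liver (Mus musculus) for metabolic stability, read by LC-MS, with NADPH named in the record, with a stated time of 60 min, tested at 1 uM, in the absence of a further agent (on this read-out higher numbers stand for a more stable compound and lower numbers for a less stable compound), gives > 95%, which is a limit of the assay rather than a number. Compound 2 `COc1ccc(-c2c(C)nc3c(N4CC[C@@H](NC(=O)c5ccccc5)C4)cc(C)nn23)cc1OC` in this assay likewise gives > 95%, again a limit and not a number. Both measured values therefore sit at the same limit: the limit of > 95% in this assay, at which 2 of the 2 values shown sit. Within the data shown here, no step between measured compounds can be drawn from these two, so there is no measured step for the pair.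

The next compound, compound 3 `COc1ccc(-c2c(C)nc3c(N4CC[C@@H](NS(=O)(=O)c5ccc(C(C)=O)cc5)C4)cc(C)nn23)cc1OC`, differs from compound 2 in one place: (4-acetylphenyl)sulfonyl in place of benzoyl on an amine nitrogen. Among the measured compounds shown here, with both measured values at the limit, the expectation for compound 3 can rest only on the shared core and the single change. The step from compound 2 to compound 3 in this assay is expected to be a number at least 10 percentage points lower from compound 2 to compound 3 (that floor lies within the scatter), that is, no more than a small drop, within or close to the scatter. Compound 3 is thus estimated at 85%, with a range from 60% to 98%, and a fair chance that the assay again reports only the limit.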

Compound 3, percent of the compound remaining: > 95%
Compound 3 ended at the assay's limit (the forecaster's own chance of this, stated with the estimate: 45%); middle value at least 10 percentage points away from the limit.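

No step can be read from compound 2 to compound 3 in this assay, because both values are limits of the assay and not numbers: the limit of > 95% in this assay, at which 3 of the 3 values shown sit.

The compounds shown leave open how far (4-acetylphenyl)sulfonyl in place of benzoyl on an amine nitrogen shifts the percent of compound remaining.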